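A few compounds are considered here, and "the series" means these few. Any claim that something is new, unique, unknown or untested is made for them only; others in the source may bear on it.

Measured so far in a functional assay on A549 cells (Homo sapiens) for antiproliferative activity, read by MTT assay, with a stated time of 48 h; on this read-out higher numbers stand for weaker inhibition and lower numbers for stronger inhibition
compound 1 `Cn1cc(C2=C(c3nn(CCCn4cncn4)c4ncccc34)C(=O)N(c3ccccc3)C2=O)c2ccccc21` gives > 100000 nM
compound 2 `Cn1cc(C2=C(c3nn(CCn4ccnc4)c4ncccc34)C(=O)N(c3ccccc3)C2=O)c2ccccc21` gives 43100 nM
compound 3 `Cn1cc(C2=C(c3nn(CCCN4CCCCC4)c4ncccc34)C(=O)N(c3cccc4ccccc34)C2=O)c2ccccc21` gives 2820 nM

Compound 1 gives a limit and not a number, and the limit of > 100000 nM in this assay, at which 1 of the 3 values shown sits, is the only such case here. Of the two true numbers, compound 2 stands highest at 43100 nM and the other number, for compound 3, is lower at 2820 nM on the same read-out.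

Next comes compound 4 `Cn1cc(C2=C(c3nn(CCn4ccnc4)c4ncccc34)C(=O)NC2=O)c2ccccc21` with the change hydrogen in place of phenyl on an amide-type nitrogen in a ring from compound 2, that is, hydrogen in place of phenyl on an amide-type nitrogen in a ring. For the measured compounds named here, no measured step changes the group at this place. Going by the values given here, the one measured step, an at least 2.3-fold lower number from compound 1 to compound 2 (0.36 log units; beyond the scatter), lies in the chain and gives only a rough scale for a single change. Compound 3 has another group on this nitrogen and also another chain, so its 2820 nM figure cannot be read as a step at this place, though it shows that lower numbers occur in the series.

With so little to go on, a modest move toward stronger inhibition is expected, and no change at all remains possible. The estimated size is a 2.4-fold lower number from compound 2 to compound 4 (0.38 log units; beyond the scatter) and it is uncertain. For compound 4 the expected value is 18000 nM with an estimated range from 4000 nM to 80000 nM in this assay.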

Compound 4, half-maximal inhibitory concentration: > 100000 nM
Compound 4 ended at the assay's limit (the forecaster's own chance of this, stated with the estimate: 12%); middle value at least 5.5-fold (0.74 log units) from the limit.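

In this assay, for the compounds shown here, this is the first measured change at the amide-type nitrogen in a ring, and replacing phenyl with hydrogen gives an at least 2.3-fold higher number from compound 2 to compound 4 (0.36 log units; beyond the scatter). The direction is therefore toward weaker inhibition, so within this pair the phenyl goes with the stronger inhibition, and on this chain the unsubstituted nitrogen gives no measurable gain. The reading for compound 4 is a limit of the assay and not a number, so the step sets only a minimum size: the limit of > 100000 nM in this assay, at which 2 of the 4 values shown sit.

From the compounds shown here alone, whether a methyl or a benzyl group on this nitrogen would keep the inhibition seen with the phenyl of compound 2 stays open, so it is unknown whether any group at this place is enough or an aromatic ring is needed. Going by these compounds, compound 3 differs from the others in both this group and the chain, so it cannot separate the two changes, and the effect of hydrogen in place of phenyl on a chain ending in an amine remains unknown.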